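From methoxy to chloro: the expected step

The source may report more compounds than this note shows. Statements on the series, on what has been measured and on what is new or still open speak of the compounds shown alone.

The series keeps one core and varies a single group on an aromatic carbon, as in compound 1 `Cc1cc(C#N)ccc1/N=c1\c(O)c(O)\c1=N/[C@H](C)C(C)(C)C`, compound 2 `CCCc1cc(C#N)ccc1/N=c1\c(O)c(O)\c1=N/[C@H](C)C(C)(C)C` and compound 3 `COc1cc(C#N)ccc1/N=c1\c(O)c(O)\c1=N/[C@H](C)C(C)(C)C`. In a functional assay for inhibition, with Rattus norvegicus as the target (on this read-out lower numbers stand for stronger inhibition and higher numbers for weaker inhibition), compound 3 gives 290 nM, the lowest number of the three, against 1080 nM for compound 1 and 23100 nM for compound 2.

The next compound is compound 4 `C[C@@H](/N=c1\c(O)c(O)\c1=N/c1ccc(C#N)cc1Cl)C(C)(C)C`. The change is chloro in place of methoxy on an aromatic carbon, ortho to a large group and meta to a cyano group.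

Among the compounds with values here, three measured steps bear on this place. Methoxy in place of methyl gave a modest 3.7-fold lower number from compound 1 to compound 3 (0.57 log units; beyond the scatter). Methoxy in place of propyl gave a large 80-fold lower number from compound 2 to compound 3 (1.90 log units; beyond the scatter), and ethyl in place of hydrogen on the chain gave a large 21-fold higher number from compound 1 to compound 2 (1.33 log units; beyond the scatter). Within the data shown here, no chloro compound has been measured, so the modest step is taken as the guide, with the sign of a loss of the methoxy group. The expected step is a 1.9-fold higher number from compound 3 to compound 4 (0.28 log units; within the scatter), a modest one towards a higher number. Compound 4 is estimated at 550 nM, with an expected range of 170 nM to 1800 nM.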

Compound 4, half-maximal inhibitory concentration: 41 nM
Compound 4: the middle estimate sits 13-fold (1.13 log units) above what was measured; measured number below the stated range.
By their numbers in this assay, from the lowest: compound 4; then compound 3; then compound 1; then compound 2.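

Chloro on this aromatic carbon, ortho to a large group and meta to a cyano group, gives the lowest number of the four in this assay with a 7.1-fold lower number from compound 3 to compound 4 (0.85 log units; beyond the scatter) and with a 26-fold lower number from compound 1 to compound 4 (1.42 log units; beyond the scatter) and also with a 560-fold lower number from compound 2 to compound 4 (2.75 log units; beyond the scatter) as the steps from the earlier groups at this place. Methoxy therefore no longer marks the low end of the series, and since methoxy brings a hydrogen-bond acceptor and chloro brings none, an acceptor on this carbon is not required for a low number among these compounds. Nothing at hand accounts for the size of the drop.

On these data alone, what fluoro, bromo or an amine would give at this place stays open. Also open, as far as these compounds go, is whether the gain seen in this assay with chloro holds on another core.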